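Shared core variants at the assay limit; compound 4 expected

The compounds below may be only part of what the source reports. "The series", "measured", "known", "first", "only" and "open" are said of these compounds alone.

The shared core is that of compound 1 `CC(C)[C@H](NC(=O)COc1cccc2ccccc12)C(=O)N[C@@H](CC(=O)O)C(=O)COc1cccc2ccccc12`; compound 2 `CC(C)[C@H](NC(=O)COc1cccc2ccccc12)C(=O)N[C@@H](CC(=O)O)C(=O)COc1cc(C(F)(F)F)cc(C(F)(F)F)c1` and compound 3 `CC(C)[C@H](NC(=O)COc1cccc2ccccc12)C(=O)N[C@@H](CC(=O)O)C(=O)COc1ccc(C#N)cc1` carry other groups on the oxygen on a saturated carbon, and compound 4 `CC(C)[C@H](NC(=O)COc1cccc2ccccc12)C(=O)N[C@@H](CC(=O)O)C(=O)COc1c(F)ccc(F)c1F` has not yet been measured. In a functional assay on Jurkat cells (Homo sapiens) (a higher number here means a weaker inhibitor, a lower number a stronger inhibitor), compound 1 gives > 100000 nM, a limit of the assay and not a number. In this assay compound 2 gives > 100000 nM, also a limit. In this assay compound 3 gives > 100000 nM, again a limit. Compound 3 thus stands where all three values shown sit, namely at the limit of > 100000 nM in this assay, at which 3 of the 3 values shown sit. The step that the two limits leave unreadable from compound 1 to compound 3 is unreadable between two limits.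

Compound 4 differs from compound 3 by 2,3,6-trifluorophenyl in place of 4-cyanophenyl on an oxygen on a saturated carbon. Among the compounds with values here, no measured step bears on this change, since the only single-place step is the unreadable one from compound 1 to compound 3, and compound 2 shares no such step with either. The estimated step from compound 3 to compound 4 is therefore a step that the limit leaves unreadable from compound 3 to compound 4, expected to stay within the scatter. Compound 4 is expected at 150000 nM in this assay, within 50000 nM to 500000 nM.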

Compound 4, half-maximal inhibitory concentration: 1200 nM
For compound 4 the middle estimate is 130-fold (2.10 log units) above the measured one; the measured number lies below the stated range.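

In this assay, the group on the oxygen on a saturated carbon proves able to move the value: 2,3,6-trifluorophenyl in place of 4-cyanophenyl gives an at least 83-fold lower number from compound 3 to compound 4 (1.92 log units; beyond the scatter), and the same group in place of naphthalen-1-yl gives an at least 83-fold lower number from compound 1 to compound 4 (1.92 log units; beyond the scatter). The steps among compound 1, compound 2 and compound 3 cannot be read, so those compounds showed no effect of this position, whereas compound 4 shows one with the rest of the shared core unchanged. Compound 4 alone stands off the limit: the limit of > 100000 nM in this assay, at which 3 of the 4 values shown sit.

Which of the three fluorines are needed remains open, as does whether a 2,3,6-trichlorophenyl or a monofluorophenyl would serve in the same place. Also open, from the compounds shown here alone, is whether the value of compound 4 holds when the carboxylic acid of the shared core is replaced by a primary amide.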